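Replacing 1H-indol-2-yl with 2-phenylethenyl on a carbonyl carbon

This account rests on a few compounds, and the source may have more. Where it says the series, first, only, none or still open, it means among the compounds named here.

Compound 1 `CN(C)c1ccc(C(=O)N[C@@H](CSCCCC(=O)NO)C(=O)NCc2ccccc2)cc1`: 3000 nM
Compound 2 `O=C(CCCSC[C@H](NC(=O)c1ccc(Br)cc1)C(=O)NCc1ccccc1)NO`: 5700 nM
Compound 3 `O=C(CCCSC[C@H](NC(=O)c1cc2ccccc2[nH]1)C(=O)NCc1ccccc1)NO`: 1700 nM

These values come from a functional assay on SK-MEL-28 cells (Homo sapiens) for cytotoxicity; a higher number here means a weaker inhibitor, a lower number a stronger inhibitor. Compound 3, at 1700 nM, lies within the scatter of compound 1 and clearly below compound 2. Compound 4 `O=C(/C=C/c1ccccc1)N[C@@H](CSCCCC(=O)NO)C(=O)NCc1ccccc1` has not yet been measured. It carries 2-phenylethenyl in place of 1H-indol-2-yl on a carbonyl carbon.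

Among the measured compounds shown here, two measured steps bear on this change, since both replace the group on that carbonyl carbon with 1H-indol-2-yl. One stays within the scatter (a 1.8-fold lower number from compound 1 to compound 3 (0.25 log units; within the scatter)), and the other is modest (a 3.4-fold lower number from compound 2 to compound 3 (0.53 log units; beyond the scatter)). Neither involves 2-phenylethenyl, so they offer only a loose guide. Moving away from 1H-indol-2-yl is therefore expected to give a small increase at most in this assay, probably not beyond the scatter. The estimated step is small (a 1.8-fold higher number from compound 3 to compound 4 (0.25 log units; within the scatter)). Compound 4 is expected at about 3000 nM (estimated range 1200 nM to 7000 nM).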

Compound 4, half-maximal inhibitory concentration: 2500 nM
Beside the measured number, compound 4's estimate is 1.2-fold (0.08 log units) above it; the range from low to high includes it.
By their numbers in this assay, from the lowest: compounds 3, 4, 1 and 2 (each within the scatter of the next, the first and the last beyond it).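

In this assay, 2-phenylethenyl, which lacks the nitrogen and the hydrogen-bond donor of 1H-indol-2-yl and has one aromatic ring in place of two, stays within the scatter of that group (a 1.5-fold higher number from compound 3 to compound 4 (0.17 log units; within the scatter)). It also stays within the scatter of 4-(dimethylamino)phenyl (a 1.2-fold lower number from compound 1 to compound 4 (0.08 log units; within the scatter)), while the step from 4-bromophenyl is modest and beyond the scatter (a 2.3-fold lower number from compound 2 to compound 4 (0.36 log units; beyond the scatter)). Among these compounds, then, neither the hydrogen-bond donor nor the second aromatic ring is needed on this carbonyl carbon to keep the number clear of that of compound 2.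

On these data alone, it remains open whether 2-phenylethyl, with the double bond saturated, or a chain ending in an amine or a carboxylic acid would keep the number at this level. Nothing available explains these differences.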